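Swapping a Tetrazole for a Fluoropyridine on the Shared Core

The compounds below may be only part of what the source reports. "The series", "measured", "known", "first", "only" and "open" are said of these compounds alone.

In a functional assay on HEK293 cells for agonist activity at Bombesin receptor subtype-3 (Homo sapiens), read by luminescence and calcium flux, with a stated time of 10 min (on this read-out higher numbers stand for an effect only at larger amounts of compound and lower numbers for an effect already at smaller amounts), compound 3 `CCC(C)(C)Cc1c[nH]c(CCc2ccc(-n3ncnn3)cc2)n1` gives 422 nM. Among the three measured compounds this is the second highest number: compound 2 `c1ccc(-c2ccc(CCc3nc(CC4CCCC4)c[nH]3)cc2)nc1` gives 425 nM, which lies within the scatter of compound 3, while compound 1 `CCC(C)(C)Cc1c[nH]c(CCc2ccc(-c3cccc(N)n3)cc2)n1` gives 37 nM, well beyond it.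

Compound 4 `CCC(C)(C)Cc1c[nH]c(CCc2ccc(-c3ccc(F)cn3)cc2)n1` has not yet been measured. It differs from compound 3 in one place: 5-fluoropyridin-2-yl in place of 2H-tetrazol-2-yl on an aromatic carbon.

Among the compounds with values here, only one measured step bears directly on this change. Going an 11-fold higher number from compound 1 to compound 3 (1.06 log units; beyond the scatter), the 6-aminopyridin-2-yl group gave way to the tetrazole and the number rose markedly. Compound 4 moves in the opposite direction, bringing back a six-membered ring with one nitrogen, though now carrying a fluorine where the amino group used to sit. Compound 2 also carries a related group, yet on a different left-hand chain, and its value sits close to that of compound 3, so the return of such a ring alone does not guarantee that the number falls all the way back. A downward step is therefore expected a 3.5-fold lower number from compound 3 to compound 4 (0.55 log units; beyond the scatter), smaller than a full reversal. Compound 4 is estimated at 120 nM, with a range from 30 nM to 500 nM.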

Compound 4, half-maximal effective concentration: 66 nM
The estimate for compound 4 lay 1.8-fold (0.26 log units) above the measured number; the measured number falls inside the stated range.
By their numbers in this assay, from the lowest: compounds 1 and 4 (each within the scatter of the next); then compounds 3 and 2 (each within the scatter of the next).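

In this assay, the position on the aromatic ring of the shared core clearly tells the tetrazole apart from a pyridine ring: putting 5-fluoropyridin-2-yl in place of 2H-tetrazol-2-yl gives a 6.4-fold lower number from compound 3 to compound 4 (0.81 log units; beyond the scatter), a step beyond the scatter. Set against the amino-bearing ring of the first compound, the same group gives a 1.8-fold higher number from compound 1 to compound 4 (0.25 log units; within the scatter), which lies within the scatter, so the amino group is not required to reach this level, and a fluorine on the pyridine ring serves about as well in this pair. The data hold no separate measurement that could explain why the two pyridine rings differ from the tetrazole.

As far as these compounds go, what a plain phenyl ring, or a methoxy group in place of the fluorine, would do on the core of compound 4 remains open. Compound 2 differs from compound 4 in more than one place, so it cannot show what the fluorine itself contributes.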